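A few compounds are considered here, and "the series" means these few. Any claim that something is new, unique, unknown or untested is made for them only; others in the source may bear on it.

In a functional assay on the whole organism with Mus musculus as the target (on this read-out lower numbers stand for an effect already at smaller amounts and higher numbers for an effect only at larger amounts of compound), compound 3 `Cc1cc(-c2ccccc2)nnc1NCCN` gives 0.5 mg/kg. Among the three measured compounds that is the second highest number. Nearest to it is compound 1 `CCCN(CCC)CCNc1nnc(-c2ccccc2)cc1C`, which gives 2 mg/kg. That difference, a 4.0-fold lower number from compound 1 to compound 3 (0.60 log units; beyond the scatter), lies beyond the scatter. Furthest from it is compound 2 `Cc1cc(-c2ccccc2)nnc1NCCCCN`, which gives 0.1 mg/kg. That difference, a 5.0-fold higher number from compound 2 to compound 3 (0.70 log units; beyond the scatter), is also beyond the scatter. Compound 4 `CNCCNc1nnc(-c2ccccc2)cc1C` differs from compound 3 in one place: methyl in place of hydrogen on an amine nitrogen. The amine nitrogen in question is the one that carries dipropylamino in compound 1, so the change from dipropylamino to amino, with its step of a 4.0-fold lower number from compound 1 to compound 3 (0.60 log units; beyond the scatter), bears most directly here. Removing both propyl groups lowered the number; adding a single methyl is expected to move it partway back up, since methylamino lies between amino and dipropylamino in size. The other measured step, a 5.0-fold higher number from compound 2 to compound 3 (0.70 log units; beyond the scatter), concerns chain length, which is unchanged here. A modest rise is therefore expected, a 2.0-fold higher number from compound 3 to compound 4 (0.30 log units; within the scatter). For compound 4 the estimate is 1 mg/kg, in a range from 0.4 mg/kg to 2.5 mg/kg.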

Compound 4, minimum effective dose: 2 mg/kg
Beside the measured number, compound 4's estimate is 2.0-fold (0.30 log units) below it; low and high end bracket the measured number.
By their numbers in this assay, from the lowest: compound 2; then compound 3; then compounds 1 and 4 (each within the scatter of the next).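

Placing a single methyl on this amine nitrogen is enough to give a 4.0-fold higher number from compound 3 to compound 4 (0.60 log units; beyond the scatter) in this assay, so the free amino end group does not tolerate even this smallest addition without a loss. Larger groups on the same nitrogen add no further measurable change, with no change at the digits printed from compound 1 to compound 4 (within the scatter), so among the compounds shown, methylamino and dipropylamino cannot be told apart. The widest gap remains the one to the longer chain, with a 20-fold higher number from compound 2 to compound 4 (1.30 log units; beyond the scatter).

No measurement available here explains these differences. As far as these compounds go, it remains open where ethylamino or dimethylamino would fall on this read-out, and whether a methyl on the end nitrogen of the longer chain in compound 2 would cost as much as it does on the shorter chain.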